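Notes on a trimethoxybenzoyl series: from compound 3 to compound 4

The compounds below may be only part of what the source reports. "The series", "measured", "known", "first", "only" and "open" are said of these compounds alone.

Measured so far in a functional assay on MCF7 cells (Homo sapiens) for cytotoxicity, read by MTT assay, with a stated time of 96 h; on this read-out higher numbers stand for weaker inhibition and lower numbers for stronger inhibition:
compound 1 `COc1cc(C(=O)c2cn(-c3cccc(Cl)c3)cc2-c2ccccc2)cc(OC)c1OC` gives 150 nM
compound 2 `COc1cc(C(=O)c2cn(-c3ccc(N)cc3)cc2-c2ccccc2)cc(OC)c1OC` gives 35 nM
compound 3 `COc1cc(C(=O)c2cn(-c3ccccc3)cc2-c2ccc(Br)cc2)cc(OC)c1OC` gives 340 nM

Compound 3 stands at the highest of the three numbers. The nearest to it is compound 1, whose number lies below it by more than the scatter; the furthest is compound 2, whose number lies well below it. Among the compounds with values here, the one step between compounds that differ in a single place is a 4.3-fold lower number from compound 1 to compound 2 (0.63 log units; beyond the scatter), a change on the aromatic nitrogen.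

Compound 4 `COc1cc(C(=O)c2cn(-c3ccccc3)cc2/C=C/c2ccccc2)cc(OC)c1OC` is not yet measured. It differs from compound 3 as follows: 2-phenylethenyl in place of 4-bromophenyl on an aromatic carbon. Within the data shown here, the change sits on an aromatic carbon of the five-membered ring, two ring bonds from the ring nitrogen, whereas the only measured step concerns the group on that nitrogen, so no measured step bears directly on this change, and no measured pair varies the group on this carbon at all. The direction and size of the step are therefore open. As a working expectation, compound 4 is estimated to give 300 nM in this assay, within a range of 80 nM to 1200 nM, which means an expected step of a 1.1-fold lower number from compound 3 to compound 4 (0.05 log units; within the scatter) and is not a firm call in either direction.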

Compound 4, half-maximal inhibitory concentration: 2200 nM
Beside the measured number, compound 4's estimate is 7.3-fold (0.87 log units) below it; measured number above the stated range.
By their numbers in this assay, from the lowest: compound 2; then compound 1; then compound 3; then compound 4.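

In this assay, within the data shown here, a 6.5-fold higher number from compound 3 to compound 4 (0.81 log units; beyond the scatter) gives the first read on the group at this aromatic carbon, two ring bonds from the ring nitrogen, and it shows that the number is sensitive to what this position carries. Both groups hold one six-membered aromatic ring of carbon only, so keeping such a ring on this carbon does not by itself keep the number; 2-phenylethenyl brings a double bond outside aromatic rings, and the bromine of 4-bromophenyl is gone. Among these compounds, the single pair does not separate these two differences, and no measurement at hand accounts for the step.

The compounds shown leave open how much of the step goes with the bromine and how much with the double bond, a question that a plain phenyl and a saturated 2-phenylethyl chain on this carbon would each address. Also open, from the compounds shown here alone, is whether the step seen here holds on other cores of the series, such as one carrying the 4-aminophenyl group on the ring nitrogen, or for the opposite geometry of the double bond.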